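Cytotoxicity notes: hydroxyphenyl position on the shared core

The source may hold more compounds than are shown below. What is called first, only, known or untested is meant among the compounds shown, and "the series" means these compounds.

Measured compounds:
compound 1 `Cc1cc(-c2ccc(O)cc2)cn2c(CSCCc3ccccc3)cnc12` — >= 100 ug/mL
compound 2 `COc1ccc(-c2cc(C)cn3c(CSCCc4ccccc4)cnc23)cc1` — 20 ug/mL

In an ADME assay on HEL cells (Homo sapiens) for cytotoxicity, with a stated time of 3 days (on this read-out higher numbers stand for lower toxicity in this test and lower numbers for higher toxicity in this test), compound 1 gives >= 100 ug/mL, and this is a limit of the assay rather than a number. Compound 1 therefore stands at the limit of >= 100 ug/mL in this assay, at which 1 of the 2 values shown sits, so where it sits within the range of low toxicity is not known. In this assay, among the compounds with values here, compound 2 gives 20 ug/mL; no step between compound 1 and compound 2 is available, so their two values are taken only as they stand.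

Compound 3 `Cc1cc(-c2cccc(O)c2)cn2c(CSCCc3ccccc3)cnc12` differs from compound 1 by 3-hydroxyphenyl in place of 4-hydroxyphenyl on an aromatic carbon. Within the data shown here, no measured step for this change exists. The step is expected to lie within the scatter, with no clear direction, so the result for compound 3 may again come back as a limit. The expected step from compound 1 to compound 3 is an at least 1.2-fold lower number from compound 1 to compound 3 (0.09 log units; that floor lies within the scatter) in this assay. Compound 3 is estimated at 80 ug/mL, with a range from 30 ug/mL to 120 ug/mL.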

Compound 3, minimum cytotoxic concentration: 20 ug/mL
For compound 3 the middle estimate is 4.0-fold (0.60 log units) above the measured one; measured number below the stated range.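

In this assay, within the data shown here, 3-hydroxyphenyl in place of 4-hydroxyphenyl gives an at least 5.0-fold lower number from compound 1 to compound 3 (0.69 log units; beyond the scatter), so on the shared core the placing of the hydroxyl on the phenyl ring matters in this test, a point the earlier compounds could not show. The two groups have the same atoms and the same counts of donors and acceptors, which ties the step to the change in attachment pattern alone. The size of the step is only a floor, set by a value of compound 1 that is a limit of the assay and not a number: the limit of >= 100 ug/mL in this assay, at which 1 of the 3 values shown sits.

Going by these compounds, it remains open whether the same contrast appears with other groups, such as 3-aminophenyl against 4-aminophenyl or the matching carboxylic acids. Also open, on these data alone, is whether it persists with a longer chain in place of the methyl group.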